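Trimethoxyphenyl lactam series: nitrophenyl replaced by amino-hydroxy-methoxyphenyl

The compounds below may be only part of what the source reports. "The series", "measured", "known", "first", "only" and "open" are said of these compounds alone.

Measured so far:
compound 1, `COc1cc(N2C(=O)[C@@H](Oc3ccccc3)[C@H]2c2ccc([N+](=O)[O-])cc2)cc(OC)c1OC`: 63000 nM
compound 2, `COc1ccc(N2C(=O)[C@@H](Oc3ccccc3)[C@H]2c2ccc(OC)c(O)c2)cc1`: 49000 nM

Both numbers come from a functional assay on MCF7 cells (Homo sapiens) for antiproliferative activity, read by MTT assay, with stated times of 24 h and 72 h; on this read-out lower numbers stand for stronger inhibition and higher numbers for weaker inhibition. Compound 1 gives 63000 nM in this assay, and compound 2 gives 49000 nM; the two lie within the usual scatter of each other, so neither can be placed ahead of the other, and both sit at weak inhibition. Within the data shown here, no step between two measured compounds that differ in one place is available, so the scale of a single change on the shared core is not yet known from these data.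

Compound 3, `COc1cc(N)c([C@@H]2[C@H](Oc3ccccc3)C(=O)N2c2cc(OC)c(OC)c(OC)c2)cc1O`, is the next case. It differs from compound 1 only at one site: a group of 10 heavy atoms (7 carbon, 1 nitrogen, 2 oxygen; one six-membered aromatic ring of carbon only) in place of a group of 9 heavy atoms (6 carbon, 1 nitrogen, 2 oxygen; one six-membered aromatic ring of carbon only), on a saturated ring carbon. The group that leaves carries the nitro function; the group that enters brings an amino and a hydroxy as two hydrogen-bond donors, on the same saturated ring carbon of the four-membered non-aromatic ring.

Among the measured compounds shown here, with no measured step of this kind to lean on, and with compound 1 and compound 2 close together despite different aryl groups, the expectation for compound 3 is a step of a 1.6-fold lower number from compound 1 to compound 3 (0.20 log units; within the scatter), which is not expected to exceed the scatter by much. Compound 3 is estimated at 40000 nM, with a range from 10000 nM to 150000 nM.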

Compound 3, half-maximal inhibitory concentration: 20000 nM
Beside the measured number, compound 3's estimate is 2.0-fold (0.30 log units) above it, within the range that was stated.
By their numbers in this assay, from the lowest: compound 3; then compounds 2 and 1 (each within the scatter of the next).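

In this assay, among these compounds, the exchange of the 4-nitrophenyl on the saturated ring carbon of the four-membered ring gives the first single-site step, a 3.2-fold lower number from compound 1 to compound 3 (0.50 log units; beyond the scatter), and this step lies beyond the scatter. It shows that the number responds to the aryl group at this position, which compound 1 and compound 2 could not show, as those two differ in more than one place. The step is modest, however, and compound 3 at 20000 nM remains in the weak part of the scale, while no separate measurement bears on the reason for the change.

The exchange removes the nitro function and brings in amino, hydroxy and methoxy substituents together, so the compounds shown do not assign the step to any one of them, or settle whether the nitro loss or the new substituents account for it. Also open, on these data alone, is how the number would respond to a single-substituent aryl group at this position, such as 4-aminophenyl, or to a carboxylic acid in place of the hydroxy.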